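Swapping one aryl group for another on a shared core

A few compounds are considered here, and "the series" means these few. Any claim that something is new, unique, unknown or untested is made for them only; others in the source may bear on it.

- compound 1 `CCCCc1cc2c(=O)c(CC)c(C)[nH]c2cc1OCCOc1ccccc1`: 1000 nM
- compound 2 `CCCCc1cc2c(=O)c(-c3ccncc3)c(C)[nH]c2cc1OCCOc1ccccc1`: 23000 nM
- compound 3 `CCCCc1cc2c(=O)c(-c3ccc(OC(F)(F)F)cc3)c(C)[nH]c2cc1OCCOc1ccccc1`: 20000 nM

In an ADME assay on J774 cells (Mus musculus) for antiproliferative activity, with a stated time of 72 h (a higher number here means that more compound is needed for the effect, a lower number that less compound is needed), compound 3 gives 20000 nM, sharing the high end of the three numbers. Its nearest neighbour shows a 1.2-fold lower number from compound 2 to compound 3 (0.06 log units; within the scatter), and its furthest shows a 20-fold higher number from compound 1 to compound 3 (1.30 log units; beyond the scatter).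

The next structure is compound 4 `CCCCc1cc2c(=O)c(-c3ccc(C(F)(F)F)cc3F)c(C)[nH]c2cc1OCCOc1ccccc1`, in which 2-fluoro-4-(trifluoromethyl)phenyl replaces 4-(trifluoromethoxy)phenyl on an aromatic carbon: 2-fluoro-4-(trifluoromethyl)phenyl in place of 4-(trifluoromethoxy)phenyl on an aromatic carbon.

The closest guide is the exchange of one aromatic group for another, a 1.2-fold lower number from compound 2 to compound 3 (0.06 log units; within the scatter), which stayed within the scatter. The two replacements of ethyl, a 23-fold higher number from compound 1 to compound 2 (1.36 log units; beyond the scatter) and a 20-fold higher number from compound 1 to compound 3 (1.30 log units; beyond the scatter), were both large, but this change involves no ethyl group, so they bear on it less directly. Among the measured compounds shown here, no measured compound carries the incoming group, so the expectation rests on three compounds alone. No step beyond the scatter is therefore expected in this assay. The expected change is a 1.3-fold lower number from compound 3 to compound 4 (0.10 log units; within the scatter). For compound 4 the estimated value is 16000 nM, with an expected range from 6000 nM to 40000 nM.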

Compound 4, half-maximal effective concentration: 19000 nM
Compound 4: middle estimate off by 1.2-fold (0.07 log units), on the low side; low and high end bracket the measured number.
By their numbers in this assay, from the lowest: compound 1; then compounds 4, 3 and 2 (each within the scatter of the next).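

In this assay, a further aromatic group at this position, 2-fluoro-4-(trifluoromethyl)phenyl, gives no separation from the other two, with a 1.1-fold lower number from compound 3 to compound 4 (0.02 log units; within the scatter) and a 1.2-fold lower number from compound 2 to compound 4 (0.08 log units; within the scatter). Against ethyl, it shows a 19-fold higher number from compound 1 to compound 4 (1.28 log units; beyond the scatter), so each of the three aromatic groups shown, whether pyridin-4-yl, 4-(trifluoromethoxy)phenyl or this one, stands apart from ethyl by a large step, and exchanging one for another has so far made no difference beyond the scatter. Nothing available here accounts for this outcome.

The compounds shown leave open whether a propyl chain or a methyl group in place of ethyl would stay near compound 1 or move toward the aromatic compounds. They also leave open whether a phenyl ring carrying an amine or a carboxylic acid would remain level with compounds 2, 3 and 4.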